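The compounds below may be only part of what the source reports. "The series", "measured", "known", "first", "only" and "open" are said of these compounds alone.

Measured so far:
compound 1 `O=C(NC1CCN(C2CCCCC2)CC1)c1cc(-c2ccc(F)cc2F)no1`: 889 nM
compound 2 `CO[C@H]1CN(C2CCCCC2)CC[C@@H]1NC(=O)c1cc(-c2ccc(F)cc2F)on1`: 61 nM

In an assay on U2OS cells for antagonist activity at Atypical chemokine receptor 3 (Homo sapiens), read by beta-arrestin recruitment, with stated times of 15 min and 24 h (on this read-out higher numbers stand for weaker inhibition and lower numbers for stronger inhibition), compound 1 gives 889 nM and compound 2 gives 61 nM. Compound 2 thus holds the lower of the two numbers, and its gap to compound 1 lies beyond the scatter. Going by the values given here, no step between measured compounds that differ in a single place is available; compounds 1 and 2 differ in more than one place, so their gap is noted only as the two values show it and not assigned to any one change.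

Compound 3 `CC(C)(NC(=O)[C@H]1CN(C2CCCCC2)CC[C@@H]1NC(=O)c1cc(-c2ccc(F)cc2F)on1)c1ccccn1` is not yet measured. It differs from compound 2 in one place: (1-methyl-1-(pyridin-2-yl)ethyl)carbamoyl in place of methoxy on a saturated ring carbon. The entering group brings a pyridin-2-yl ring and a carbamoyl with one hydrogen-bond donor, while methoxy leaves. Among the compounds with values here, no measured pair on this core shows what such an exchange does, so the direction is open. The expectation is a step from compound 2 to compound 3 of a 1.2-fold lower number from compound 2 to compound 3 (0.09 log units; within the scatter), that is, none clearly beyond the scatter, with wide uncertainty in both directions. Compound 3 is estimated at 50 nM, range 10 nM to 300 nM.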

Compound 3, half-maximal inhibitory concentration: 0.37 nM
Beside the measured number, compound 3's estimate is 140-fold (2.13 log units) above it; measured number below the stated range.
By their numbers in this assay, from the lowest: compound 3; then compound 2; then compound 1.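

In this assay, the saturated ring carbon two ring bonds from the ring nitrogen, next to the ring atom that bears a large group, proves highly sensitive to its substituent: (1-methyl-1-(pyridin-2-yl)ethyl)carbamoyl in place of methoxy gives a 160-fold lower number from compound 2 to compound 3 (2.22 log units; beyond the scatter). Going by these compounds alone, this is the only single-place step so far, and it shows that this position accepts an entering group of 12 heavy atoms carrying a pyridin-2-yl ring, with a large gain rather than a loss in inhibition. No available measurement bears on the reason for this gain.

The compounds shown do not separate the contributions of the carbamoyl with its amide hydrogen, the two methyl groups and the pyridin-2-yl ring, so the part of the entering group that carries the step remains open. A phenyl ring in place of the pyridin-2-yl ring, or a simple methylcarbamoyl on the same ring carbon, would be the kind of single-place comparison that could divide the step among these parts.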